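The source may report more compounds than this note shows. Statements on the series, on what has been measured and on what is new or still open speak of the compounds shown alone.

Three compounds that share one core have so far been put through a functional assay on the whole organism (strain Wistar) for inhibition, with Rattus norvegicus as the target, read by paw edema, with stated times of 3 h and 1 h, at a dose of 6 mg/kg by the oral route; a lower number here means less inhibition, a higher number more inhibition at the dose given (going by the name of the read-out). Compound 1 `O=C(CO[N+](=O)[O-])NNC(=O)c1ccc(-n2[nH]c(=O)cc2-c2ccc([N+](=O)[O-])cc2)cc1` gives 24% in this assay. Compound 2 `O=C(CO[N+](=O)[O-])NNC(=O)c1ccc(-n2[nH]c(=O)cc2-c2ccc(Cl)cc2)cc1`, which carries chloro in place of nitro on an aromatic carbon, gives 5.84%, a step of a number 18.2 percentage points lower from compound 1 to compound 2 (beyond the scatter). Compound 3 `CCOC(=O)c1c(-c2ccc([N+](=O)[O-])cc2)n(-c2ccc(C(=O)NNC(=O)CO[N+](=O)[O-])cc2)[nH]c1=O`, with ethoxycarbonyl in place of hydrogen on an aromatic carbon of the core, gives 22.2%, a step of a number 1.8 percentage points lower from compound 1 to compound 3 (within the scatter); compound 3 thus stands second highest of the three numbers, within the scatter of compound 1 and well above compound 2.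

The unmeasured compound 4 `CCOC(=O)c1c(-c2ccccc2)n(-c2ccc(C(=O)NNC(=O)CO[N+](=O)[O-])cc2)[nH]c1=O` differs from compound 3 in one place: hydrogen in place of nitro on an aromatic carbon. Cut one bond further out, the 4-nitrophenyl becomes phenyl. Within the data shown here, the only measured step that touches the nitro group is the one from compound 1 to compound 2, which cost a number 18.2 percentage points lower from compound 1 to compound 2 (beyond the scatter). Removing the nitro group altogether is expected to act in the same direction, so for compound 4 a step of about a number 14.2 percentage points lower from compound 3 to compound 4 (beyond the scatter) is expected. Compound 4 is therefore estimated at 8% in this assay, within a range from 0% to 20%.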

Compound 4, a percentage reported as inhibition, in the whole organism at one dose (the size of the read-out at that dose, not a potency): 59.6%
Beside the measured number, compound 4's estimate is 51.6 percentage points below it, outside the stated range (above it).
By their numbers in this assay, from the lowest: compound 2; then compounds 3 and 1 (each within the scatter of the next); then compound 4.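

In this assay, going from 4-nitrophenyl to phenyl on the ester-bearing core gives a number 37.4 percentage points higher from compound 3 to compound 4 (beyond the scatter), so the nitro group is not needed for a high number at this place. Among these compounds, the only earlier step at this place, a number 18.2 percentage points lower from compound 1 to compound 2 (beyond the scatter), ran the other way, although that step put chloro in place of nitro on the core without ethoxycarbonyl. Changes at this one place can therefore move the number either way, and by a wide margin. Nothing given here bears on why the number moves as it does.

As far as these compounds go, it remains open whether the plain phenyl group would also give a high number without the ethoxycarbonyl group, and how chloro would behave with it. Where a methoxy group or an amine at this same place would fall also remains open.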